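The source may hold more compounds than are shown below. What is called first, only, known or untested is meant among the compounds shown, and "the series" means these compounds.

Compound 1 `Cc1ccc2nc(NC(=O)CNC(=O)c3nn(-c4ccccc4)c(=O)c4ccccc34)sc2c1` gives 35 nM in an assay on L cells for inhibition of Protein-serine O-palmitoleoyltransferase porcupine (Mus musculus), read by reporter gene assay, with a stated time of 24 h (on this read-out lower numbers stand for an effect already at smaller amounts and higher numbers for an effect only at larger amounts of compound), the highest of the three numbers at hand. Compound 3 `COc1ccc(-n2nc(C(=O)NCC(=O)Nc3nc4ccc(C)cc4s3)c3ccccc3c2=O)cc1` gives 25 nM, and the step of a 1.4-fold lower number from compound 1 to compound 3 (0.15 log units; within the scatter) comes from a methoxy in place of hydrogen on an aromatic carbon. Compound 2 `O=C(CSc1nc2c(c(=O)n1-c1ccccc1)SCC2)Nc1ccc(-c2ccccn2)cc1`, built on a different core, gives 4 nM. Compound 4 `O=C(CNC(=O)c1nn(-c2ccccc2)c(=O)c2ccccc12)Nc1nc2ccc(Cl)cc2s1` differs from compound 1 by chloro in place of methyl on an aromatic carbon, a chloro in place of methyl on the 6-methyl-1,3-benzothiazol-2-yl group. Among the measured compounds shown here, no measured step touches this group; the one single-point step available sits elsewhere in the molecule and lies within the scatter. The step from compound 1 to compound 4 is therefore expected to stay within the scatter, no change at the digits printed from compound 1 to compound 4 (within the scatter). Compound 4 is estimated at 35 nM, between 12 nM and 100 nM.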

Compound 4, half-maximal effective concentration: 30 nM
Compound 4: the middle estimate sits 1.2-fold (0.07 log units) above what was measured; low and high end bracket the measured number.
By their numbers in this assay, from the lowest: compound 2; then compounds 3, 4 and 1 (each within the scatter of the next).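

Chloro in place of methyl, turning the 6-methyl-1,3-benzothiazol-2-yl group into the 6-chloro-1,3-benzothiazol-2-yl group, gives a 1.2-fold lower number from compound 1 to compound 4 (0.07 log units; within the scatter) in this assay. Among the compounds shown here, this is the first reading at this position, where the earlier compounds showed no single-point change, and these two substituents cannot be told apart by their numbers. Nothing at hand offers an explanation for this result.

On these data alone, whether the position would accept a methoxy, a nitrile or an amine equally well remains open. So does the effect of hydrogen there, with neither methyl nor chloro present.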